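Halogen swap on the sulfonyl aryl ring: working notes

The compounds below may be only part of what the source reports. "The series", "measured", "known", "first", "only" and "open" are said of these compounds alone.

Measured in a functional assay on QGY-7703 cells (Homo sapiens) for cytotoxicity, read by MTT assay, with a stated time of 24 h; a lower number here means a stronger inhibitor, a higher number a weaker inhibitor:
compound 1 `O=C1/C(=C/c2cccnc2)CN(S(=O)(=O)c2ccc(Cl)cc2)C/C1=C\c1ccccc1F` gives 12100 nM
compound 2 `O=C1/C(=C/c2cccnc2)CN(S(=O)(=O)c2ccc(Br)cc2)C/C1=C\c1ccccc1F` gives 12800 nM
compound 3 `O=C1/C(=C/c2ccncc2)CN(S(=O)(=O)c2ccc(Cl)cc2)C/C1=C\c1ccccc1C(F)(F)F` gives 12700 nM

Compound 4 `O=C1/C(=C/c2ccncc2)CN(S(=O)(=O)c2ccc(Br)cc2)C/C1=C\c1ccccc1C(F)(F)F` has not yet been measured. Compound 1 and compound 2 differ in one place: bromo in place of chloro on an aromatic carbon. The resulting step in this assay is a 1.1-fold higher number from compound 1 to compound 2 (0.02 log units; within the scatter). Compound 3 and compound 4 differ by the same change at the same place: bromo in place of chloro on an aromatic carbon. The difference between the core of compound 1 and the core of compound 3 is not broken down here; in this assay the two values lie within the scatter of each other, and so do those of compound 2 and compound 3.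

For compound 4 in this assay the expected step is a 1.0-fold higher number from compound 3 to compound 4 (0.01 log units; within the scatter). Going by the values given here, this rests on the one measured instance of the change, where a 1.1-fold higher number from compound 1 to compound 2 (0.02 log units; within the scatter) remained within the scatter. Compound 4 is therefore estimated at 13000 nM, between 7000 nM and 25000 nM.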

Compound 4, half-maximal inhibitory concentration: 7060 nM
Compound 4: middle estimate off by 1.8-fold (0.27 log units), on the high side; measured number inside the range.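

Bromo in place of chloro, carried to a second core, gives a 1.8-fold lower number from compound 3 to compound 4 (0.25 log units; within the scatter) in this assay. Set beside the first instance, the two steps do not differ by more than repeated measurement would allow: the same change on two cores in this assay, a 1.1-fold higher number (0.02 log units; within the scatter) from compound 1 to compound 2 and a 1.8-fold lower number (0.25 log units; within the scatter) from compound 3 to compound 4, 1.9-fold (0.28 log units) apart, within the scatter of two such steps. The change therefore shows no detectable dependence on the core across these two pairs, but with each step within the scatter, this does not establish a real effect of the swap on either core, nor does it show how the change would behave on other cores.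

Still open, on these data alone, is whether a group other than the two halogens, such as a methoxy, a nitrile or an amine, at the same place on the sulfonyl aryl ring would give a step beyond the scatter.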